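A few compounds are considered here, and "the series" means these few. Any claim that something is new, unique, unknown or untested is made for them only; others in the source may bear on it.

Compound 1 `COc1ccc(-c2nc(/N=C(\N)[N+]3(C)CCCCC3)sc2-c2ccc(OC)cc2)cc1`: in a functional assay with Oryctolagus cuniculus as the target (a lower number here means a stronger inhibitor, a higher number a weaker inhibitor), compound 1 gives > 1000 nM, which is a limit of the assay, not a number.
Compound 2 `COc1ccc(-c2nc(/N=C(\N)n3ccnc3)sc2-c2ccc(OC)cc2)cc1`: in this assay compound 2 gives > 100 nM, again only a limit.
Compound 3 `COc1ccc(-c2nc(C(=O)N3CCCCC3CCO)sc2-c2ccc(OC)cc2)cc1`: in this assay compound 3 gives 45 nM.

Compound 2 therefore stands on a limit, and the two limits the limit of > 100 nM in this assay, at which 1 of the 3 values shown sits, and the limit of > 1000 nM in this assay, at which 1 of the 3 values shown sits, leave the step that the two limits leave unreadable from compound 1 to compound 2 unreadable. Compound 4 `COc1ccc(-c2nc(/C=C/C(=O)O)sc2-c2ccc(OC)cc2)cc1` differs from compound 2 in that (a group of 5 heavy atoms (3 carbon, 2 oxygen; no ring) in place of a group of 8 heavy atoms (4 carbon, 4 nitrogen; one five-membered aromatic ring with 2 hetero atoms), on an aromatic carbon). Among the compounds with values here, no measured step bears on this change, and the one known step gives no size. Within the data shown here, compound 3 carries a different group on the same ring carbon and gives a number, but no step from it is known. Compound 4 is expected to give 300 nM, in the range 60 nM to 1500 nM. The expected step that the limit leaves unreadable from compound 2 to compound 4 cannot be sized against a limit.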

Compound 4, half-maximal inhibitory concentration: > 100 nM
Compound 4: no number, only a limit; the forecaster's own chance of this, stated with the estimate: 30%; the middle value is on the limit's open side.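

Within the data shown here, compound 4 gives only a limit in this assay, and no step linking it to compound 1 or compound 2 can be read. The compounds shown leave open how strong compound 1, compound 2 and compound 4 actually are.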